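The source may hold more compounds than are shown below. What is called first, only, known or untested is meant among the compounds shown, and "the series" means these compounds.

Compound 1 `CCCCC/C(C)=N/Nc1nc(-c2cccc(OC)c2)cs1` was tested in an assay on isolated protein for inhibition of Amine oxidase [flavin-containing] B (Homo sapiens), read by fluorescence (a higher number here means a weaker inhibitor, a lower number a stronger inhibitor), where compound 1 gives 6720 nM. Alongside it stands compound 2 `COc1cccc(-c2csc(N/N=C/c3cccnc3)n2)c1`, which in this assay gives 2910 nM. Of these two numbers, compound 1 carries the higher one, and its gap to compound 2 lies beyond the usual scatter, so compound 1 counts as the weaker inhibitor of the pair.

The next compound, compound 3 `COc1cccc(-c2csc(N/N=C(\C)c3ccco3)n2)c1`, keeps the shared core of compound 1 and changes one piece: furan-2-yl in place of pentyl on a carbon with a double bond to nitrogen. Pentyl, a plain chain of five carbons, is swapped for furan-2-yl, a five-membered aromatic ring with one hetero atom and one hydrogen-bond acceptor.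

Among the measured compounds shown here, no measured pair shows this exact swap, so the size of the step is uncertain. The expectation is a moderate move toward a lower number, with the step from a 2.7-fold lower number from compound 1 to compound 3 (0.43 log units; beyond the scatter) estimated as more than the scatter. Compound 3 is expected to give about 2500 nM in this assay, within a range of 800 nM to 8000 nM.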

Compound 3, half-maximal inhibitory concentration: 1680 nM
Compound 3: middle estimate off by 1.5-fold (0.17 log units), on the high side, and the stated range covers the measured number.
By their numbers in this assay, from the lowest: compounds 3 and 2 (each within the scatter of the next); then compound 1.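

Swapping pentyl for furan-2-yl on a carbon with a double bond to nitrogen gives, in this assay, a 4.0-fold lower number from compound 1 to compound 3 (0.60 log units; beyond the scatter) and this modest step lies beyond the scatter. Among the compounds shown here, it is the first direct reading at this position: with the shared core held fixed and the same number of heavy atoms entering as leaving, an aromatic ring carrying a hydrogen-bond acceptor gives a stronger inhibitor than the plain chain. No measurement here explains why the number falls, so the step records a change in strength and not its cause.

This single swap cannot separate the effect of the ring from that of its oxygen; phenyl or thiophen-2-yl in the same place would help tell them apart. On these data alone, whether a shorter chain such as ethyl would also improve on pentyl stays open.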